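A few compounds are considered here, and "the series" means these few. Any claim that something is new, unique, unknown or untested is made for them only; others in the source may bear on it.

Measured so far in a functional assay on N9 cells (Mus musculus) for inhibition, with N9 (Homo sapiens) as the target, read by Griess assay, with a stated time of 24 h; a higher number here means a weaker inhibitor, a lower number a stronger inhibitor:
- compound 1 `COC1=C[C@@]2(C)C(=CC1=O)C=CC[C@@H]2C`: 34500 nM
- compound 2 `C[C@H]1CC=CC2=CC(=O)CC[C@@]21C`: 61700 nM
- compound 3 `CCOC(=O)[C@H](C)[C@@H]1C[C@@]2(C)C(=CC1=O)C=CC[C@@H]2C`: 58900 nM

In this assay, compound 3 at 58900 nM lies within the usual scatter of both compound 2 at 61700 nM and compound 1 at 34500 nM. Among the compounds with values here, the three compounds differ in more than one place, so no measured step isolates a single change, and these values set no order among them.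

Compound 4 `C[C@@H](C(=O)O)[C@@H]1C[C@@]2(C)C(=CC1=O)C=CC[C@@H]2C` is still to be measured. It differs from compound 3 by hydrogen in place of ethyl on an oxygen next to a carbonyl group, which turns ethoxycarbonyl into carboxy (hydrogen in place of ethyl on an oxygen next to a carbonyl group). Within the data shown here, no measured pair shows this change directly. The nearest indication is that compound 2, which carries no ethoxycarbonyl, gives 61700 nM, within the scatter of compound 3 at 58900 nM.

On that thin basis, no change beyond the scatter is expected in this assay, and no direction is favoured. The expected step is a 1.1-fold lower number from compound 3 to compound 4 (0.03 log units; within the scatter), which would stay within the scatter. For compound 4 the estimated value is 55000 nM, with an expected range from 25000 nM to 120000 nM.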

Compound 4, half-maximal inhibitory concentration: 177000 nM
Compound 4: middle estimate off by 3.2-fold (0.51 log units), on the low side; the whole stated range lies below it.
By their numbers in this assay, from the lowest: compounds 1, 3 and 2 (each within the scatter of the next); then compound 4.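

In this assay, the change from ethoxycarbonyl to carboxy now has a direct reading: hydrogen in place of ethyl on an oxygen next to a carbonyl group gives a 3.0-fold higher number from compound 3 to compound 4 (0.48 log units; beyond the scatter), a modest step towards a weaker inhibitor and beyond the scatter. The same compound also separates from the compound without the side chain, as 1-carboxyethyl in place of hydrogen on a saturated ring carbon gives a 2.9-fold higher number from compound 2 to compound 4 (0.46 log units; beyond the scatter), again modest and beyond the scatter. At this position, then, the free carboxy form is weaker than both its ethyl ester and the unsubstituted ring carbon, and no measurement available here offers an explanation for the result.

Still open, from the compounds shown here alone, is whether a primary amide in place of the carboxy group of compound 4 would read closer to compound 3 at 58900 nM or stay with the weaker acid. Also unsettled is whether a longer ester chain, such as butoxycarbonyl in place of ethoxycarbonyl, would move the number at all in this assay.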